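The source may report more compounds than this note shows. Statements on the series, on what has been measured and on what is new or still open speak of the compounds shown alone.

Measured so far in a functional assay for antagonist activity at Alpha-1A adrenergic receptor (Oryctolagus cuniculus); a higher number here means weaker binding, a lower number tighter binding:
- compound 1 `CN(C)C(=O)c1cccnc1NCCCN1CCN(c2ccccc2)CC1` — 6.31 nM
- compound 2 `CN(C)C(=O)c1cccnc1NCCCN1CCN(c2ccccc2OC(F)(F)F)CC1` — 3.16 nM

Compound 2 holds the lower of the two numbers in this assay, though its gap to compound 1 falls within the scatter, so the two are not separated. Among the compounds with values here, the only measured step is a 2.0-fold lower number from compound 1 to compound 2 (0.30 log units; within the scatter), trifluoromethoxy in place of hydrogen on an aromatic carbon; it does not show a change beyond the scatter.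

The next compound, compound 3 `CN(C)C(=O)c1cccnc1NCCCN1CCN(c2ccccc2-c2ncco2)CC1`, differs from compound 2 as follows: 1,3-oxazol-2-yl in place of trifluoromethoxy on an aromatic carbon. Within the data shown here, no measured step touches an exchange of one group for another at this carbon; the single step on hand only shows that placing a group there versus hydrogen left the number essentially unchanged. On that basis the expectation for this assay is a step of modest size at most, with no clear direction, and most likely within the scatter. Compound 3 is therefore expected to give a number near that of compound 2, the estimated step being a 1.6-fold higher number from compound 2 to compound 3 (0.20 log units; within the scatter). Compound 3 is estimated at 5 nM, within a range of 1.5 nM to 16 nM.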

Compound 3, dissociation constant: 0.316 nM
Estimate against measurement, compound 3: 16-fold (1.20 log units) above; measured number outside the range, below it.
By their numbers in this assay, from the lowest: compound 3; then compounds 2 and 1 (each within the scatter of the next).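

In this assay, the aromatic carbon ortho to a large group proves far more responsive than the earlier pair suggested: a 10-fold lower number from compound 2 to compound 3 (1.00 log units; beyond the scatter) when 1,3-oxazol-2-yl replaces trifluoromethoxy, and a 20-fold lower number from compound 1 to compound 3 (1.30 log units; beyond the scatter) when it replaces hydrogen. Both exchanged groups have 5 heavy atoms and no net charge, so heavy-atom count does not separate them, although the entering group has one five-membered aromatic ring with 2 hetero atoms and 2 hydrogen-bond acceptors, while the leaving group has no ring and 1 hydrogen-bond acceptor. No measurement is available that bears on the reason for this difference.

The compounds shown leave open whether the step follows the aromatic ring itself or its hetero atoms, a question that a phenyl ring or a 1,3-thiazol-2-yl group on this carbon would address. They also leave open whether 1,3-oxazol-2-yl would give a comparable step on any other carbon of the six-membered aromatic ring, since it appears at this single place in the series.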